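Replacing the 5-nitrothiophen-3-yl group of compound 2

This account rests on a few compounds, and the source may have more. Where it says the series, first, only, none or still open, it means among the compounds named here.

In a functional assay on HL-60 cells (Homo sapiens) for inhibition, read by MTT assay, with a stated time of 48 h, tested at 10 uM (on this read-out higher numbers stand for more inhibition of growth at the one concentration tested and lower numbers for less inhibition of growth), compound 1 `Cc1oc2c([C@H]3CCN(C)C[C@H]3O)c(O)cc(O)c2c(=O)c1C(O)c1ccc(Cl)cc1` gives 2%, and compound 2 `Cc1oc2c([C@H]3CCN(C)C[C@H]3O)c(O)cc(O)c2c(=O)c1C(O)c1csc([N+](=O)[O-])c1` gives 45%, the higher of the two numbers. Compound 3 `COc1ccc(C(O)c2c(C)oc3c([C@H]4CCN(C)C[C@H]4O)c(O)cc(O)c3c2=O)cc1Br` differs from compound 2 as follows: 3-bromo-4-methoxyphenyl in place of 5-nitrothiophen-3-yl on a saturated chain carbon bound to an aromatic carbon and an oxygen on a saturated carbon. It has 3-bromo-4-methoxyphenyl in place of 5-nitrothiophen-3-yl. For the measured compounds named here, the only measured step bearing on this is large, a number 43 percentage points higher from compound 1 to compound 2 (beyond the scatter), and it introduced the same 5-nitrothiophen-3-yl group in place of 4-chlorophenyl. Compound 3 returns to a six-membered aromatic ring of carbon only, so a large fall is expected, a number 31 percentage points lower from compound 2 to compound 3 (beyond the scatter). Compound 3 is estimated at 14%, with an expected range of 0% to 38%.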

Compound 3, percent growth inhibition at one concentration: 23%
Estimate against measurement, compound 3: 9 percentage points below, and the stated range covers the measured number.
By their numbers in this assay, from the lowest: compound 1; then compound 3; then compound 2.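

Within this assay, a six-membered aromatic ring of carbon only does not by itself fix a low number at this saturated chain carbon: 3-bromo-4-methoxyphenyl in place of 4-chlorophenyl gives a number 21 percentage points higher from compound 1 to compound 3 (beyond the scatter) and so recovers part of the gain. The 5-nitrothiophen-3-yl group still stays ahead, with a number 22 percentage points lower from compound 2 to compound 3 (beyond the scatter) on the change to 3-bromo-4-methoxyphenyl. No evidence here explains either step.

Whether the nitro group or the thiophene ring accounts for that lead stays open. So does the outcome with a nitrophenyl group, or with a phenyl ring bearing an amine or a carboxylic acid.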